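The compounds below may be only part of what the source reports. "The series", "measured", "known", "first", "only" and "open" are said of these compounds alone.

In an ADME assay on MAGI cells (Homo sapiens) for cytotoxicity (a higher number here means that more compound is tolerated, a lower number that less compound is tolerated), three compounds have been tested so far: compound 1 `NCCCCN(C[C@@H]1CN(C(=O)c2ccco2)CCN1)[C@H]1CCCc2cccnc21`, compound 2 `NCCCCN(C[C@@H]1CN(C(=O)OCc2ccccc2)CCN1)[C@H]1CCCc2cccnc21` and compound 3 `NCCCCN(C[C@H]1CNCCN1)[C@H]1CCCc2cccnc21`. Compound 1 gives > 10 uM, which is a limit of the assay and not a number. Compound 2 gives > 10 uM, again a limit. Compound 3 gives > 10 uM, also a limit, so no number places it among the others. The whole set stands at one mark: the limit of > 10 uM in this assay, at which 3 of the 3 values shown sit.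

Compound 4 `NCCCCN(C[C@@H]1CNCCN1)[C@H]1CCCc2cccnc21` is the counterpart of compound 3, and the difference is the two compounds have the same atoms and bonds and differ only in configuration as drawn: 1 of 2 stereo elements differ; a stereocentre at a saturated ring carbon is drawn R in compound 3 and S in compound 4. Going by the values given here, the one measured step, a step that the two limits leave unreadable from compound 1 to compound 2, has no readable size and concerns the group on a carbonyl carbon, not this stereocentre. Among the compounds with values here, no measured step tests a change of configuration, so no shift in either direction beyond the scatter is expected in this assay. The expectation rests on compound 3 with its limit of > 10 uM. The expected step is a step that the limit leaves unreadable from compound 3 to compound 4. For compound 4 the estimated value is 20 uM, with an expected range from 10 uM to 60 uM, and a report as a limit again is the likeliest outcome.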

Compound 4, half-maximal toxic concentration: > 10 uM
Compound 4: a limit, no number; the forecaster's own chance of this, stated with the estimate: 85%; the middle value lies beyond the limit too.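

In this assay, going by these compounds alone, compound 4 gives > 10 uM, a limit and not a number, so no step from compound 1, compound 2 or compound 3 to compound 4 can be read. The compounds shown leave open whether configuration or the group on the ring nitrogen changes tolerance at all.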